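Swapping the group on the sulfonyl sulfur of compound 2

This account rests on a few compounds, and the source may have more. Where it says the series, first, only, none or still open, it means among the compounds named here.

Compound 1 `O=S(=O)(Nc1ccc2oc(-c3ccccc3)nc2c1)c1cccc(C(F)(F)F)c1` sits at a limit of an assay on cells for inhibition of HSP60/HSP10 (Homo sapiens), with a stated time of 60 min (a higher number here means a weaker inhibitor, a lower number a stronger inhibitor), > 100000 nM, not at a measured number.
Compound 3 `O=S(=O)(Nc1ccc2oc(-c3ccccc3)nc2c1)c1ccc(C(F)(F)F)cc1` also sits at a limit of this assay, > 100000 nM.
Compound 2 `O=S(=O)(Nc1ccc(-c2nc3ccccc3o2)cc1)c1ccc(Cl)s1` gives a number in this assay, 31000 nM.

Within the data shown here, compound 2 therefore holds the only real value shown; the other two stop at the limit of > 100000 nM in this assay, at which 2 of the 3 values shown sit. Compound 4 `COc1cccc(S(=O)(=O)Nc2ccc(-c3nc4ccccc4o3)cc2)c1` is not yet measured. It differs from compound 2 in one place: 3-methoxyphenyl in place of 5-chlorothiophen-2-yl on a sulfonyl sulfur. Among the measured compounds shown here, no step between two measured compounds tells how much such a change shifts this assay, so the step from compound 2 to compound 4 is expected to be small, within the usual scatter, with a fair chance that compound 4 returns only a limit. Compound 4 is expected to give 45000 nM, between 15000 nM and 100000 nM. The step expected is a 1.5-fold higher number from compound 2 to compound 4 (0.16 log units; within the scatter).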

Compound 4, half-maximal inhibitory concentration: 80000 nM
Compound 4: middle estimate off by 1.8-fold (0.25 log units), on the low side; the measured number falls inside the stated range.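

The group on the sulfonyl sulfur matters in this assay: 3-methoxyphenyl in place of 5-chlorothiophen-2-yl gives a 2.6-fold higher number from compound 2 to compound 4 (0.41 log units; beyond the scatter). Among these compounds, this is the first step that can be read between two measured compounds, and it shows that this position responds to a change of ring, though only modestly. Compound 1 and compound 3 add no step to it: the limit of > 100000 nM in this assay, at which 2 of the 4 values shown sit.

This one step cannot separate the effect of the ring from that of the chlorine or the methoxy. Going by these compounds, what an amine or a carboxylic acid in place of the methoxy would do also remains open.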